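Cyclopropyl Hydroxamate in Place of the Propanoic Acid

The source may report more compounds than this note shows. Statements on the series, on what has been measured and on what is new or still open speak of the compounds shown alone.

Measured compounds:
compound 1 `O=C(O)c1ccc(NCc2cccc(Oc3ccccc3)c2)cc1` — 86%
compound 2 `Cc1nc(-c2ccc(C(F)(F)F)cc2)sc1CNc1ccc(CC(C)C(=O)O)cc1` — 100%

Among the measured compounds shown here, in a functional assay on CHO cells for agonist activity at Free fatty acid receptor 1 (Homo sapiens), read by a luciferase reporter (a lower number here means a smaller maximal response, a higher number a larger maximal response), compound 2 reaches 100%, the higher of the two numbers, and the only other measured compound, compound 1, gives 86%, a gap that lies beyond the usual scatter. For the measured compounds named here, no step between measured compounds shares one change, so the record offers no direct precedent for the move to compound 3 `Cc1nc(-c2ccc(C(F)(F)F)cc2)sc1CNc1ccc([C@H]2C[C@@H]2C(=O)NO)cc1`. The change is 2-(hydroxycarbamoyl)cyclopropyl in place of 2-carboxypropyl on an aromatic carbon. Going by the values given here, because the only anchor is compound 2 at 100%, which already sits at the top of the scale, the step can only hold or fall. The expected step for compound 3 is a number 22 percentage points lower from compound 2 to compound 3 (beyond the scatter), a modest decrease that may reach beyond the scatter. In this assay compound 3 is estimated at 78%, within 50% to 100%.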

Compound 3, largest response reached (reported as percent of maximum), in percent of the reference or control that the assay uses: 78%
For compound 3 middle estimate and measured number coincide at the digits printed; the range from low to high includes it.
By their numbers in this assay, from the lowest: compounds 3 and 1 (each within the scatter of the next); then compound 2.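

In this assay, among the compounds shown here, placing 2-(hydroxycarbamoyl)cyclopropyl instead of 2-carboxypropyl on this aromatic carbon, para to a large group, gives a number 22 percentage points lower from compound 2 to compound 3 (beyond the scatter), the only step read at this position. Compounds 1 and 2 both carry a carboxylic acid, whereas compound 3 has none and still reaches 78%, so a substantial maximal response at this position does not depend on that acid. No measurement shown here accounts for the step.

The change alters the chain and the terminal group together, so a 2-carboxycyclopropyl group would be needed to separate the contribution of the cyclopropyl ring from that of the hydroxamate. Also open, as far as these compounds go, are the other stereoisomers of the cyclopropyl group and whether a tetrazole at this position would hold the response.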